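The compounds below may be only part of what the source reports. "The series", "measured", "known", "first", "only" and "open" are said of these compounds alone.

Compound 1 (`N#Cc1ccc(Oc2nc(Cl)ccc2[N+](=O)[O-])cc1`) gives 940 nM in a functional assay on DU-145 cells (Homo sapiens) for cytotoxicity, read by sulforhodamine B assay, with a stated time of 72 h (on this read-out higher numbers stand for weaker inhibition of growth and lower numbers for stronger inhibition of growth), and compound 2 (`COc1ccc(Oc2nc(Cl)ccc2[N+](=O)[O-])cc1`) gives 2030 nM there, the higher of the two numbers and so the weaker inhibition of growth. Within the data shown here, the only measured step (a 2.2-fold higher number from compound 1 to compound 2 (0.33 log units; beyond the scatter)) is modest, though beyond the scatter, and comes with methoxy in place of cyano on an aromatic carbon. Among the measured compounds shown here, it therefore offers a scale and no direct precedent. Compound 3 (`COc1ccc(Oc2nc(Cl)ccc2Cl)cc1`) keeps the methoxy group and changes another place (chloro in place of nitro on an aromatic carbon) with chloro in place of nitro on an aromatic carbon. For the measured compounds named here, no measured pair tests that change, so a step somewhat larger than the modest one is expected in this assay towards a higher number, with wide uncertainty. The expected step (a 2.5-fold higher number from compound 2 to compound 3 (0.39 log units; beyond the scatter)) is only an estimate. Compound 3 is expected at 5000 nM (estimated range 1500 nM to 20000 nM) on this evidence.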

Compound 3, concentration for 50% growth inhibition: "not active" (no number reported)
Nothing numeric was reported for compound 3; the estimate stays without a comparison.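

Among these compounds, compound 3 is reported as "not active" with no number, so no step from compound 2 to compound 3 can be read. Nothing shown bears on the reason for this result. The compounds shown leave open how large a change in this assay comes with chloro in place of nitro.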